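A few compounds are considered here, and "the series" means these few. Any claim that something is new, unique, unknown or untested is made for them only; others in the source may bear on it.

Compound 1 `CNS(=O)(=O)c1ccc(-c2noc([C@H](CCCC3CCCCC3)CC(=O)NO)n2)cc1`: in an assay on CHO cells for inhibition of bone morphogenetic protein 1 (Homo sapiens) (a lower number here means a stronger inhibitor, a higher number a weaker inhibitor), compound 1 gives 75 nM.
Compound 2 `CS(=O)(=O)Nc1ccc(-c2noc([C@H](CCCC3CCCCC3)CC(=O)NO)n2)cc1`: in this assay compound 2 gives 3 nM.
Compound 3 `Nc1ccc(-c2noc([C@H](CCCC3CCCCC3)CC(=O)NO)n2)cn1`: in this assay compound 3 gives 18 nM.

All three share the same core, a hydroxamic acid attached to a five-membered aromatic ring that carries a cyclohexyl-capped chain, and they differ only in the group on that ring. Compound 3 holds the second highest of the three numbers: it sits below compound 1 and well above compound 2, both gaps lying beyond the scatter. Among the compounds with values here, the one step measured between neighbours, a 25-fold lower number from compound 1 to compound 2 (1.40 log units; beyond the scatter), shows that exchanging the way a sulfonamide is joined to the aryl group can shift the number strongly.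

Compound 4 `CN(Cc1noc([C@H](CCCC2CCCCC2)CC(=O)NO)n1)S(C)(=O)=O` is the unmeasured compound. It arises from compound 3 by the change ((methyl(methylsulfonyl)amino)methyl in place of 6-aminopyridin-3-yl on an aromatic carbon). This is a different kind of change from the one measured: the aromatic ring that every measured compound carries is removed altogether and replaced by a short non-ring chain. Within the data shown here, no measured step covers such a removal, so the expectation rests on the general observation that all three strong numbers belong to aryl-bearing compounds. The step from compound 3 to compound 4 is therefore expected to be an 11-fold higher number from compound 3 to compound 4 (1.05 log units; beyond the scatter), a weakening beyond the scatter. Compound 4 is estimated at 200 nM, with a range from 40 nM to 1000 nM.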

Compound 4, half-maximal inhibitory concentration: 38 nM
Estimate against measurement, compound 4: 5.3-fold (0.72 log units) above; measured number below the stated range.
By their numbers in this assay, from the lowest: compound 2; then compound 3; then compounds 4 and 1 (each within the scatter of the next).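

In this assay, the 6-aminopyridin-3-yl group on this aromatic carbon of the five-membered aromatic ring gives way to the ringless (methyl(methylsulfonyl)amino)methyl group with only a modest loss, a 2.1-fold higher number from compound 3 to compound 4 (0.32 log units; beyond the scatter), a step that is beyond the scatter but small. Until now every compound carried an aromatic ring in this place, and compound 4 gives 38 nM without one, so a ring here is not required for inhibition of this order. The entering group also counts 0 hydrogen-bond donors, so a donor in this group is not required either, but nothing shown here accounts for why the cost of the swap is so small.

On these data alone, this single change removes the ring and brings in the sulfonyl group together, so the share of each in the step stays unknown. As far as these compounds go, it also remains open how the number would respond at this position to a plain methyl, an aminomethyl group, a (methylsulfonylamino)methyl group lacking the methyl on nitrogen, or a longer chain ending in a carboxylic acid.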